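The source may hold more compounds than are shown below. What is called first, only, known or untested is meant among the compounds shown, and "the series" means these compounds.

Measured compounds:
Compound 1, `CC(=O)OCCO[C@H](CC=C(C)C)C1=CC(=O)c2c(O)ccc(O)c2C1=O`: 41500 nM
Compound 2, `CCC(O)CO[C@H](CC=C(C)C)C1=CC(=O)c2c(O)ccc(O)c2C1=O`: 28700 nM
Compound 3, `CC(C)=CC[C@@H](OC(=O)CC(O)c1ccccc1)C1=CC(=O)c2c(O)ccc(O)c2C1=O`: 44500 nM

The three compounds were tested in a functional assay on HeLa cells (Homo sapiens) for cytotoxicity, read by MTT assay; a lower number here means a stronger inhibitor, a higher number a weaker inhibitor. Their three numbers sit close together: compound 3 gives 44500 nM, compound 1 gives 41500 nM, and compound 2 gives 28700 nM, and none of these pairs is separated by more than the usual scatter, so compound 3 cannot be set apart from the other two.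

Compound 4, `CCC(C)(O)CC(=O)O[C@H](CC=C(C)C)C1=CC(=O)c2c(O)ccc(O)c2C1=O`, has not yet been measured. It differs from compound 3 in one place: 1-hydroxy-1-methylpropyl in place of hydroxy(phenyl)methyl on a saturated chain carbon bound to a carbonyl carbon

Among the compounds with values here, only one measured step is available for comparison, a 1.4-fold lower number from compound 1 to compound 2 (0.16 log units; within the scatter). That step swaps a side-chain end group on an ether-linked chain rather than on the ester of compound 3, and it stayed inside the scatter. Within the data shown here, nothing among the measured compounds addresses an exchange of an aromatic ring for a short branched chain on the acyl side. The step is therefore expected to be a 1.1-fold lower number from compound 3 to compound 4 (0.05 log units; within the scatter), with no direction beyond the scatter. Compound 4 is estimated at 40000 nM, within 18000 nM to 90000 nM.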

Compound 4, half-maximal inhibitory concentration: 25200 nM
Compound 4: the middle estimate sits 1.6-fold (0.20 log units) above what was measured; the measured number falls inside the stated range.
By their numbers in this assay, from the lowest: compounds 4, 2, 1 and 3 (each within the scatter of the next).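

In this assay, 1-hydroxy-1-methylpropyl in place of hydroxy(phenyl)methyl on a saturated chain carbon bound to a carbonyl carbon gives a 1.8-fold lower number from compound 3 to compound 4 (0.25 log units; within the scatter), which shows that the six-membered aromatic ring can leave this position without a shift beyond the scatter. Changing the group on an oxygen on a saturated carbon to (2-hydroxy-2-methylbutyl)carbonyl also stays within the scatter, with a 1.1-fold lower number from compound 2 to compound 4 (0.06 log units; within the scatter) from 2-hydroxybutyl and a 1.6-fold lower number from compound 1 to compound 4 (0.22 log units; within the scatter) from 2-acetoxyethyl, so neither change separates these compounds. No measurement shown offers an explanation for how closely these numbers agree.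

The compounds shown leave open whether an amine or a carboxylic acid in place of the hydroxy group of 1-hydroxy-1-methylpropyl, or a longer chain at this position, would give a step beyond the scatter. They also leave open how any change to the shared core would register in this assay, since all four compounds carry it unchanged.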